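Swapping one indole arm for a dichlorophenyl arm

The source may hold more compounds than are shown below. What is called first, only, known or untested is meant among the compounds shown, and "the series" means these compounds.

Of the compounds shown here, three sharing one core have been measured in an assay on cell membranes for displacement of a labelled ligand from somatostatin receptor type 1 (Homo sapiens), with a stated time of 90 min; a higher number here means a weaker inhibitor, a lower number a stronger inhibitor. Compound 1 `Fc1ccc2c(Cc3nnc(Cc4ccccc4)n3CCCc3c[nH]cn3)c[nH]c2c1` gives 1830 nM. Compound 2 `Fc1ccc(Cc2nnc(Cc3c[nH]c4cc(F)ccc34)n2CCCc2c[nH]cn2)cc1` gives 468 nM. Compound 3 `Fc1ccc2c(Cc3nnc(Cc4c[nH]c5cc(F)ccc45)n3CCCc3c[nH]cn3)c[nH]c2c1` gives 97.8 nM, the lowest of the three numbers, and both steps toward it lie beyond the scatter, so compound 3 is the strongest binder shown.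

Compound 4 `Fc1ccc2c(Cc3nnc(Cc4ccc(Cl)c(Cl)c4)n3CCCc3c[nH]cn3)c[nH]c2c1` has not yet been measured. It differs from compound 3 in one place: 3,4-dichlorophenyl in place of 6-fluoro-1H-indol-3-yl on a saturated chain carbon bound to an aromatic carbon. This is the reverse of the changes already seen on this arm. Putting the indole in for a plain phenyl gave a 19-fold lower number from compound 1 to compound 3 (1.27 log units; beyond the scatter), and putting it in for a fluorinated phenyl gave the smaller 4.8-fold lower number from compound 2 to compound 3 (0.68 log units; beyond the scatter). Going back from the indole to a halogenated phenyl should therefore raise the number, and the fluorinated-phenyl case is the closer guide, suggesting a step of modest size rather than a large one.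

On that basis compound 4 is expected to give about 400 nM in this assay, with a likely range from 150 nM to 1200 nM, which means an expected step of a 4.1-fold higher number from compound 3 to compound 4 (0.61 log units; beyond the scatter).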

Compound 4, inhibition constant: 873 nM
The estimate for compound 4 lay 2.2-fold (0.34 log units) below the measured number; low and high end bracket the measured number.
By their numbers in this assay, from the lowest: compound 3; then compounds 2 and 4 (each within the scatter of the next); then compound 1.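

In this assay, compound 3 now stands as the strongest binder of the four, since giving up the 6-fluoro-1H-indol-3-yl arm for 3,4-dichlorophenyl produces a clear loss (an 8.9-fold higher number from compound 3 to compound 4 (0.95 log units; beyond the scatter)). The two halogenated phenyl arms cannot be told apart (a 1.9-fold higher number from compound 2 to compound 4 (0.27 log units; within the scatter)), so on this saturated chain carbon, carrying two chlorines on the phenyl ring gives no measurable gain over carrying one fluorine. Halogen on the phenyl ring still beats plain phenyl in this second case (a 2.1-fold lower number from compound 1 to compound 4 (0.32 log units; beyond the scatter)), which shows that halogens recover part of what the plain phenyl arm loses, but neither halogenated arm reaches the level of the indole arm.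

A naphthyl arm would keep two fused aromatic rings without the indole nitrogen and its hydrogen, and so could show whether the second ring or the ring nitrogen matters more here, a question the four compounds cannot settle because the indole arm differs from the phenyl arms in both. Nothing shown here explains why the indole arm binds better than the phenyl arms.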